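Low Cytotoxicity Readings and a Methyl in Place of Nitro

The source may hold more compounds than are shown below. What is called first, only, known or untested is meant among the compounds shown, and "the series" means these compounds.

Values in a toxicity assay on NIH3T3 cells (Mus musculus) for cytotoxicity, read by resazurin assay; a higher number here means that more compound is needed for the effect, a lower number that less compound is needed:
- compound 1 `COC(=O)c1ccc(NCc2cncn2Cc2ccc([N+](=O)[O-])cc2)cc1-c1ccccc1`: > 10000 nM (a limit)
- compound 2 `O=[N+]([O-])c1ccc(Cn2cncc2CNc2cccc(-c3ccccc3)c2)cc1`: 10000 nM
- compound 3 `COC(=O)c1ccc(NCc2cncn2Cc2ccc(Br)cc2)cc1-c1ccccc1`: > 10000 nM (a limit)

For the measured compounds named here, compound 2, at 10000 nM, holds the only actual number in the set. The other two entries are limits and not numbers. Compound 4 `Cc1ccc(Cn2cncc2CNc2cccc(-c3ccccc3)c2)cc1` has methyl in place of nitro on an aromatic carbon, para to a large group, a change from 4-nitrophenyl to 4-methylphenyl: methyl in place of nitro on an aromatic carbon.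

Going by the values given here, two measured steps bear on this change. The closer is a step that the two limits leave unreadable from compound 1 to compound 3, where bromo replaces nitro on an aromatic carbon. The other is a number no higher from compound 1 to compound 2 (the limit leaves the size open), where hydrogen replaces methoxycarbonyl on an aromatic carbon. Neither step has a readable size. What the set does show is the limit of > 10000 nM in this assay, at which 2 of the 3 values shown sit.

Given (the limit of > 10000 nM in this assay, at which 2 of the 3 values shown sit), no step beyond the scatter and no particular direction is expected, and the estimate in this assay is no change at the digits printed from compound 2 to compound 4 (within the scatter). The estimated value for compound 4 is 10000 nM, with an expected range from 5000 nM to 20000 nM.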

Compound 4, half-maximal effective concentration: 10000 nM
Estimate against measurement, compound 4: no gap at the digits printed, and the stated range covers the measured number.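

In this assay, for the compounds shown here, the change from 4-nitrophenyl to 4-methylphenyl gives no change at the digits printed from compound 2 to compound 4 (within the scatter), the only step in the set whose size can be read, as the earlier steps cannot be read. It shows that, on this aromatic carbon para to a large group, nitro with its hydrogen-bond acceptors can give way to methyl, which has none, with no change in the reading at the digits printed. That flat step should be read alongside the other values in the set: the limit of > 10000 nM in this assay, at which 2 of the 4 values shown sit.

The compounds shown leave open whether an amine, a carboxylic acid or a longer chain at this position would read any differently. They also leave open whether methyl in place of nitro would read the same on the core of compound 1, which carries methoxycarbonyl.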